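The compounds below may be only part of what the source reports. "The series", "measured", "known", "first", "only" and "open" are said of these compounds alone.

In a functional assay on HCT-116 cells (Homo sapiens) for inhibition, read by sulforhodamine B assay, with a stated time of 48 h, tested at 50 uM (on this read-out lower numbers stand for less inhibition of growth and higher numbers for more inhibition of growth at the one concentration tested), three related compounds have been measured so far. Compound 1 (`COc1cc(/C=C/C(=O)/C=C/c2cccc3ccccc23)ccc1OCc1cn(CCCCCOc2cc(=O)oc3ccccc23)nn1`) gives 42%, the lowest of the three. Compound 2 (`COc1ccccc1/C=C/C(=O)/C=C/c1ccc(OCc2cn(CCCOc3cc(=O)oc4ccccc34)nn2)c(OC)c1`) gives 53% and compound 3 (`COc1cc(/C=C/C(=O)/C=C/c2ccccc2)ccc1OCc1cn(CCOc2cc(=O)oc3ccccc23)nn1`) gives 56%, both higher than compound 1 by more than the usual scatter. Compound 4 (`COc1cc(/C=C/C(=O)/C=C/c2cc(OC)c(OC)c(OC)c2)ccc1OCc1cn(CCCCCOc2cc(=O)oc3ccccc23)nn1`) has 3,4,5-trimethoxyphenyl in place of naphthalen-1-yl on a double-bonded chain carbon bound to a double-bonded chain carbon. Among the measured compounds shown here, no measured pair shows this change alone, since compound 2 and compound 3 differ from compound 1 in more than one place. Only a small rise, within the scatter, is therefore expected in this assay. The estimated change is a number 7 percentage points higher from compound 1 to compound 4 (within the scatter). In this assay, the estimate for compound 4 is 49%, with an expected range of 36% to 62%.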

Compound 4, percent growth inhibition at one concentration: 53%
Estimate against measurement, compound 4: 4 percentage points below; measured number inside the range.
By their numbers in this assay, from the lowest: compound 1; then compounds 2, 4 and 3 (each within the scatter of the next).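

In this assay, 3,4,5-trimethoxyphenyl in place of naphthalen-1-yl on a double-bonded chain carbon bound to a double-bonded chain carbon gives a number 11 percentage points higher from compound 1 to compound 4 (beyond the scatter). Among the compounds shown here, this is the first change at this position that can be read on its own, and it shows that growth inhibition depends on the group placed here. Nothing measured explains the rise.

Going by these compounds, it remains open whether the methoxy groups or the loss of the second aromatic ring matters more. On these data alone, how an amine or a carboxylic acid at this position would compare also remains open.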